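Chain-extended carbamates: half-life holds steady across the series

A few compounds are considered here, and "the series" means these few. Any claim that something is new, unique, unknown or untested is made for them only; others in the source may bear on it.

Measured compounds and values in an ADME assay for metabolic stability, read by HPLC, at pH 7.4; on this read-out lower numbers stand for a shorter-lived compound and higher numbers for a longer-lived compound:
compound 1, `CCCCCCCCCNC(=O)Oc1ccc(Cl)cc1C(=O)Nc1cccc(Cl)c1`, 43 h;
compound 2, `CCCCCCCCCCNC(=O)Oc1ccc(Cl)cc1C(=O)Nc1cccc(Cl)c1`, 43 h;
compound 3, `CCCCCNC(=O)Oc1ccc(Cl)cc1C(=O)Nc1ccc(Cl)cc1`, 43 h.

Compound 1 and compound 2 share the same core and differ only in the carbamate chain: methyl in place of hydrogen on a saturated chain carbon, nine bonds along the chain from an amide-type nitrogen. In this assay that change made no change at the digits printed from compound 1 to compound 2 (within the scatter), so the longer chain of compound 2 is indistinguishable from compound 1 within the scatter.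

Compound 3 carries a different core; how its core differs from that of compound 1 is not broken down here. In this assay compound 3 stands level with compounds 1 and 2 at the digits shown.

Compound 4, `CCCCCCNC(=O)Oc1ccc(Cl)cc1C(=O)Nc1ccc(Cl)cc1`, is not yet measured. Compared with compound 3 the change is methyl in place of hydrogen on a saturated chain carbon, five bonds along the chain from an amide-type nitrogen. This is the same kind of change as that from compound 1 to compound 2, though the place is not identical: there the methyl enters nine bonds along the chain from the amide-type nitrogen, here five bonds along the chain. Among the compounds with values here, only one such step is measured, so the expectation rests on a single pair.

The step from compound 3 to compound 4 is expected to be no change at the digits printed from compound 3 to compound 4 (within the scatter), because the step of no change at the digits printed from compound 1 to compound 2 (within the scatter) showed no change within the scatter for the same kind of change on the other core, and because compound 3 already sits at 43 h alongside compounds 1 and 2. Compound 4 is therefore estimated at 43 h, with a likely range from 25 h to 75 h.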

Compound 4, half-life: 43 h
Beside the measured number, compound 4's estimate shows no gap at the digits printed; measured number inside the range.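

In this assay, methyl in place of hydrogen on a saturated chain carbon, five bonds along the chain from an amide-type nitrogen, gave no change at the digits printed from compound 3 to compound 4 (within the scatter). Set beside the earlier step on the core of compound 1, the same kind of change reads alike on both cores, so within this small set it carries from one core to the other without a visible difference: the same change on two cores in this assay, no change at the digits printed (within the scatter) from compound 1 to compound 2 and no change at the digits printed (within the scatter) from compound 3 to compound 4, 1.0-fold (0.00 log units) apart, within the scatter of two such steps

This rests on two pairs only, with the methyl entering at a different place along the chain in each, and every compound shown reads the same half-life, so it shows no more than an absence of change for these two steps; it does not show that the result would hold at other places along the chain, on a third core, or for a change other than this one.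

The compounds shown leave open whether the half-life in this assay stays level with a much shorter chain such as ethyl or propyl, or with a cyclohexyl ring in place of the chain. Also open, on these data alone, is what a chain carrying an amine or a carboxylic acid would read on either core.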